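Nitro in place of hydrogen on compound 2

The source may hold more compounds than are shown below. What is called first, only, known or untested is meant among the compounds shown, and "the series" means these compounds.

In a functional assay on T98G cells (Homo sapiens) for cytotoxicity, read by MTT assay, with a stated time of 48 h (on this read-out higher numbers stand for weaker inhibition and lower numbers for stronger inhibition), compound 2 `C/C(=N\NC(=S)Nc1ccccc1)c1ccccn1` gives 6.81 nM and compound 1 `C/C(=N\NC(=S)Nc1cccc(F)c1)c1ccccn1` gives 12 nM, so the two measured compounds lie within the scatter of each other and neither can be ranked above the other. The next compound, compound 3 `C/C(=N\NC(=S)Nc1cccc([N+](=O)[O-])c1)c1ccccn1`, differs from compound 2 by a single change: nitro in place of hydrogen on an aromatic carbon. Going by the values given here, only one measured step bears on this change, the exchange between fluoro and hydrogen on an aromatic carbon, which amounts to a 1.8-fold lower number from compound 1 to compound 2 (0.25 log units; within the scatter). That step shows no effect beyond the scatter in this assay, but it is a single step and involves no nitro group. From the compounds shown here alone, no measurement with nitro exists yet, so the direction remains open and the range must stay wide. The expected change is small, and the estimate is a 1.9-fold higher number from compound 2 to compound 3 (0.28 log units; within the scatter). Compound 3 is expected to give about 13 nM, with an estimated range of 3.5 nM to 50 nM.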

Compound 3, half-maximal inhibitory concentration: 140 nM
Beside the measured number, compound 3's estimate is 11-fold (1.03 log units) below it, outside the stated range (above it).
By their numbers in this assay, from the lowest: compounds 2 and 1 (each within the scatter of the next); then compound 3.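

In this assay, the position on the six-membered aromatic ring, meta to a large group, proves sensitive to what it carries: nitro in place of hydrogen gives a 21-fold higher number from compound 2 to compound 3 (1.31 log units; beyond the scatter), and nitro in place of fluoro gives a 12-fold higher number from compound 1 to compound 3 (1.07 log units; beyond the scatter). The earlier exchange at this position gave only a 1.8-fold lower number from compound 1 to compound 2 (0.25 log units; within the scatter), so hydrogen and fluoro could not be told apart, whereas nitro stands clearly apart from both and the position can no longer be read as indifferent to substitution. The data offered here give no account of why nitro has so large an effect on this read-out.

The three compounds leave open whether this rise belongs to nitro alone or would also follow from other groups at the same position, such as an amine, a carboxylic acid, a methoxy group or a longer chain. They also leave open whether nitro would give a similar step on another carbon of this ring, since every substituted compound shown carries its group at this one position.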